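A few compounds are considered here, and "the series" means these few. Any claim that something is new, unique, unknown or untested is made for them only; others in the source may bear on it.

Measured so far:
- compound 1, `c1ccc(-c2cn3ccnc3c(-c3ccc4ncn(C5CCCCC5)c4c3)n2)cc1`: 37.3%
- compound 2, `CC(=O)c1ccc(-c2cn3ccnc3c(-c3ccc4ncn(C5CCCCC5)c4c3)n2)cc1`: 3.02%

Both were tested in a functional assay on U-251 cells (Homo sapiens) for inhibition, read by sulforhodamine B assay, with a stated time of 48 h, tested at 10 uM; on this read-out lower numbers stand for less inhibition and higher numbers for more inhibition at the one concentration tested (going by the name of the read-out). Compound 1 gives 37.3%, and compound 2, the lower of the two, gives 3.02%. Within the data shown here, the one step available, a number 34.3 percentage points lower from compound 1 to compound 2 (beyond the scatter), shows that putting an acetyl on the phenyl costs a large share of the inhibition.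

Compound 3, `FC(F)(F)c1cccc(-c2cn3ccnc3c(-c3ccc4ncn(C5CCCCC5)c4c3)n2)c1`, has not been measured yet. It differs from compound 2 in one place: 3-(trifluoromethyl)phenyl in place of 4-acetylphenyl on an aromatic carbon. The step from compound 1 to compound 2 bears on this change, since the 4-acetylphenyl that leaves is the very group whose arrival produced the large drop a number 34.3 percentage points lower from compound 1 to compound 2 (beyond the scatter). Among the measured compounds shown here, the 3-(trifluoromethyl)phenyl that enters has no counterpart among the measured compounds, so its own effect is unknown. Because the drop a number 34.3 percentage points lower from compound 1 to compound 2 (beyond the scatter) followed the arrival of the acetyl that now leaves, compound 3 is expected to recover part of the loss, with an upward step of a number 22 percentage points higher from compound 2 to compound 3 (beyond the scatter) in this assay. For compound 3 the estimate in this assay is 25%, within a range from 5% to 50%.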

Compound 3, a percentage reported as inhibition, at one concentration (the size of the read-out at that concentration, not a potency): 5.93%
Estimate against measurement, compound 3: 19.1 percentage points above; measured number inside the range.
By their numbers in this assay, from the lowest: compounds 2 and 3 (each within the scatter of the next); then compound 1.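

In this assay, exchanging 4-acetylphenyl for 3-(trifluoromethyl)phenyl gives a number 2.9 percentage points higher from compound 2 to compound 3 (within the scatter), so these two substituted phenyl groups cannot be told apart in this test. The low number is therefore not unique to the acetyl: trifluoromethyl on the phenyl, a different group at a different spot on that ring, also comes with a number 31.4 percentage points lower from compound 1 to compound 3 (beyond the scatter), and among the compounds shown, any substituent on the phenyl goes with a large loss compared with hydrogen. No measurement is available that explains why either group has this effect.

Going by these compounds, the two substituted compounds differ in both the group and its place on the phenyl, so it remains open whether 4-(trifluoromethyl)phenyl or 3-acetylphenyl would behave the same way, and thus whether the group or its position matters more. On these data alone, it is also open whether every substituent on this phenyl goes with a loss, or whether a different group, such as an amine or a methoxy group, would keep or even raise the inhibition seen with compound 1.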